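The source may hold more compounds than are shown below. What is called first, only, known or untested is meant among the compounds shown, and "the series" means these compounds.

Compound 1 `ClCc1ccccc1Cn1cnc2c(Cl)nc(Cl)nc21` and compound 2 `ClCc1cccc(Cn2cnc3c(Cl)nc(Cl)nc32)c1` are built from the same atoms joined differently; the difference between the two cores is not broken down here. In a functional assay on DU-145 cells (Homo sapiens) for cytotoxicity, read by sulforhodamine B assay, with a stated time of 48 h (a higher number here means a weaker inhibitor of growth, a lower number a stronger inhibitor of growth), compound 1 gives 2950 nM and compound 2 gives 2950 nM, level at the digits given, together the lowest of the three numbers. Compound 3 `Nc1nc(Cl)c2ncn(Cc3ccccc3CCl)c2n1` carries amino in place of chloro on an aromatic carbon and gives 32400 nM in this assay; the step of an 11-fold higher number from compound 1 to compound 3 (1.04 log units; beyond the scatter) is large. Compound 4 `Nc1nc(Cl)c2ncn(Cc3cccc(CCl)c3)c2n1` is not yet measured and carries amino in place of chloro on an aromatic carbon, the same change at a place described in the same words. The step of an 11-fold higher number from compound 2 to compound 4 (1.04 log units; beyond the scatter) is expected to match an 11-fold higher number from compound 1 to compound 3 (1.04 log units; beyond the scatter), since the change is the same and compound 2 stands at 2950 nM, level with compound 1. Compound 4 is thus expected to give 32000 nM in this assay, between 14000 nM and 75000 nM.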

Compound 4, concentration for total growth inhibition: 16600 nM
The estimate for compound 4 lay 1.9-fold (0.29 log units) above the measured number; the range from low to high includes it.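

In this assay amino in place of chloro on an aromatic carbon gives a 5.6-fold higher number from compound 2 to compound 4 (0.75 log units; beyond the scatter) and so moves the number in the same direction on the core of compound 2 as on the core of compound 1. The two steps cannot be told apart in size: the same change on two cores in this assay, an 11-fold higher number (1.04 log units; beyond the scatter) from compound 1 to compound 3 and a 5.6-fold higher number (0.75 log units; beyond the scatter) from compound 2 to compound 4, 2.0-fold (0.29 log units) apart, within the scatter of two such steps

Among the compounds shown here, this supports carrying the change between these two cores, but rests on only two pairs and does not show that it would carry to any other core.

The compounds shown leave open how other groups on that aromatic carbon, such as a methoxy group or a methylamino group, would compare with chloro and amino. On these data alone, whether the change behaves alike in other cell lines also remains open.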